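The source may hold more compounds than are shown below. What is called first, only, known or untested is meant among the compounds shown, and "the series" means these compounds.

Of the compounds shown here, three built on two closely related cores have been tested in a functional assay on HepG2 cells (Homo sapiens) for cytotoxicity, with a stated time of 24 h; a higher number here means a weaker inhibitor, a lower number a stronger inhibitor. Compound 1 `COc1cc(Cl)ccc1C(=S)Nc1ccc(Cl)cc1O` gives 5110 nM in this assay. Compound 2 `COc1cc(Cl)ccc1C(=S)Nc1ccc(Br)cc1O` differs from compound 1 in one place: bromo in place of chloro on an aromatic carbon. In this assay compound 2 gives 3880 nM. The step is a 1.3-fold lower number from compound 1 to compound 2 (0.12 log units; within the scatter). Compound 3 `COc1ccc(Cl)cc1C(=S)Nc1cc(Cl)ccc1O` is made of the same atoms as compound 1, joined differently; the difference between the two cores is not broken down here. In this assay compound 3 gives 8600 nM, the highest of the three numbers, though its gap to compound 1 lies within the scatter and only its gap to compound 2 lies beyond it.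

Compound 4 `COc1ccc(Cl)cc1C(=S)Nc1cc(Br)ccc1O` has not yet been measured. It differs from compound 3 by bromo in place of chloro on an aromatic carbon. Among the compounds with values here, this is the same kind of change as the one from compound 1 to compound 2, but not the same: in compound 2 the entering group is meta to a hydroxy group and para to a large group, whereas in compound 4 it is meta to a large group and para to a hydroxy group. Within the data shown here, the one measured instance of this kind of change gave a 1.3-fold lower number from compound 1 to compound 2 (0.12 log units; within the scatter), a shift within the scatter, and the surroundings differ only in which neighbour is where. The step here is therefore expected to be small as well, about a 1.3-fold lower number from compound 3 to compound 4 (0.11 log units; within the scatter). Compound 4 is estimated at 6600 nM, with a likely range from 3000 nM to 14000 nM.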

Compound 4, half-maximal inhibitory concentration: 8740 nM
Compound 4: the middle estimate sits 1.3-fold (0.12 log units) below what was measured, and the stated range covers the measured number.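

On the core of compound 3, putting bromo in place of chloro gives a 1.0-fold higher number from compound 3 to compound 4 (0.01 log units; within the scatter) in this assay. Set beside the same swap on the core of compound 1, the two steps do not differ by more than repeated measurements would, so as far as these pairs can tell, the change carries over from one core to the other: the same change on two cores in this assay, a 1.3-fold lower number (0.12 log units; within the scatter) from compound 1 to compound 2 and a 1.0-fold higher number (0.01 log units; within the scatter) from compound 3 to compound 4, 1.3-fold (0.13 log units) apart, within the scatter of two such steps This does not show that the swap has the same real effect on both cores or that it would behave this way on any further core, since each step is too small to separate from the scatter, so the agreement amounts to two pairs in one cytotoxicity assay that each show no clear shift.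

As far as these compounds go, in these compounds the place in question holds only chloro or bromo, so it remains open whether a fluoro, a methyl group, an amine or a carboxylic acid there would move the number by more than the scatter. Also open, from the compounds shown here alone, is what would follow from changing other parts of the shared core, such as a carbonyl in place of the thiocarbonyl or a methoxy group in place of the hydroxy group.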